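Cyclohexyl in place of neopentyl: working notes

The source may report more compounds than this note shows. Statements on the series, on what has been measured and on what is new or still open speak of the compounds shown alone.

In a functional assay on a cell-free system (plasma, Homo sapiens), with a stated time of 3 min (on this read-out lower numbers stand for stronger inhibition and higher numbers for weaker inhibition), compound 1 `CC(C)(C)OC[C@@H](O)C(=O)N1[C@H](C(=O)NCc2cc(Cl)ccc2-n2cnnn2)C[C@@H]2C[C@@H]21` gives 500 nM and compound 2 `CC(C)(C)C[C@@H](O)C(=O)N1N=CC[C@H]1C(=O)NCc1cc(Cl)ccc1-n1cnnn1` gives 590 nM. These two values lie within the scatter of each other, so compound 2 stands level with compound 1. Compound 3 `O=C(NCc1cc(Cl)ccc1-n1cnnn1)[C@@H]1CC=NN1C(=O)[C@H](O)C1CCCCC1`, not yet measured, has cyclohexyl in place of neopentyl on a saturated chain carbon bound to a carbonyl carbon and an oxygen on a saturated carbon. Within the data shown here, no measured pair covers this exchange, and no shift beyond the scatter is expected in this assay. The expected size is a 1.3-fold lower number from compound 2 to compound 3 (0.12 log units; within the scatter). For compound 3 the estimated value is 450 nM, with an expected range of 150 nM to 1300 nM.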

Compound 3, half-maximal inhibitory concentration: 970 nM
Compound 3: the middle estimate sits 2.2-fold (0.33 log units) below what was measured; the measured number falls inside the stated range.
By their numbers in this assay, from the lowest: compounds 1, 2 and 3 (each within the scatter of the next).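

In this assay, cyclohexyl in place of neopentyl on this saturated chain carbon gives a 1.6-fold higher number from compound 2 to compound 3 (0.22 log units; within the scatter), so this position accepts a six-membered carbon ring in place of an open chain with no shift beyond the scatter. Among these compounds, this is the first single-place step, and it rests on one pair. No measurement here accounts for the size of this step.

Still open, on these data alone, is whether a phenyl or a smaller isopropyl at this position would give a shift beyond the scatter. Also open, as far as these compounds go, is whether an amine or carboxylic acid on the cyclohexyl would do so.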